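Benzamide series: N-methyl core analogues, toluoyl substitution

The source may hold more compounds than are shown below. What is called first, only, known or untested is meant among the compounds shown, and "the series" means these compounds.

Measured compounds:
compound 1 `Cc1ccc(C(=O)Nc2ccc(-c3nc4c([nH]3)c(=O)n(C)c(=O)n4C)cc2)cc1` gives 13900 nM in an assay for inhibition of Amine oxidase [flavin-containing] B (Mus musculus), read by fluorescence, with a stated time of 30 min, in the presence of a further agent that is not named here; a higher number here means a weaker inhibitor, a lower number a stronger inhibitor
compound 2 `Cn1c(=O)c2c(nc(-c3ccc(NC(=O)c4ccccc4)cc3)n2C)n(C)c1=O` gives 8900 nM in this assay

Compound 2 has the lower of the two numbers recorded so far, but compound 1 sits closest to it and the gap between them lies within the usual scatter, so the two are not distinguished. Among the compounds with values here, compound 1 and compound 2 differ in more than one place, and no single step between them is available; only their two values can be compared.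

Compound 3 `Cc1ccc(C(=O)Nc2ccc(-c3nc4c(c(=O)n(C)c(=O)n4C)n3C)cc2)cc1` is the direct counterpart of compound 2: methyl in place of hydrogen on an aromatic carbon, so that the benzamido group becomes a ((4-methylphenyl)carbonyl)amino group. The same methyl is already present in compound 1 on the other core, where the value of compound 1 stands within the scatter of that of compound 2. Within the data shown here, no measured pair isolates this change, so no step size can be taken from the series. The expected step from compound 2 to compound 3 is therefore a 1.1-fold higher number from compound 2 to compound 3 (0.03 log units; within the scatter), that is none beyond the scatter. Compound 3 is estimated at 9500 nM, with a range from 4000 nM to 22000 nM.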

Compound 3, half-maximal inhibitory concentration: 11300 nM
The estimate for compound 3 lay 1.2-fold (0.08 log units) below the measured number; measured number inside the range.
By their numbers in this assay, from the lowest: compounds 2, 3 and 1 (each within the scatter of the next).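

In this assay, within the data shown here, methyl in place of hydrogen on an aromatic carbon, para to a large group, turning benzamido into ((4-methylphenyl)carbonyl)amino, gives a 1.3-fold higher number from compound 2 to compound 3 (0.10 log units; within the scatter); this is the first single-change reading at this position, and the two values are not distinguished, so this methyl leaves no mark that can be told from the scatter. The second single-change pair in the series puts a methyl group on a nitrogen of the shared core, where compound 1 carries only hydrogen, and gives a 1.2-fold lower number from compound 1 to compound 3 (0.09 log units; within the scatter), and that pair is not distinguished either, so neither of the two methyl changes separates any compounds and all three remain one group by their numbers. No measurement is available that bears on why these values fall as they do.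

As far as these compounds go, both readings rest on a single small group at each place, so it remains open whether a larger or different group on the same aromatic carbon, such as an amine, a carboxylic acid or a longer chain, would give a step beyond the scatter. The same question stands for the aromatic nitrogen of the core, where an ethyl group or a longer chain could take the place of methyl.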